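The source may report more compounds than this note shows. Statements on the series, on what has been measured and on what is new or still open speak of the compounds shown alone.

In an ADME assay on the whole organism (plasma, strain CD-1) for pharmacokinetics, with Mus musculus as the target, at a dose of 30 mg/kg by the oral route (on this read-out lower numbers stand for lower exposure and higher numbers for higher exposure at the dose given), compound 1 (`CCCS(=O)(=O)Nc1ccc(F)c(C(=O)Nc2cnc3[nH]ncc3c2)c1F`) gives 40000 ng.h/mL and lies within the scatter of compound 3 (`CCCS(=O)(=O)Nc1ccc(F)c(C(=O)Nc2cnc3[nH]cc(Br)c3c2)c1F`) at 49000 ng.h/mL while compound 2 (`CCCS(=O)(=O)Nc1ccc(Cl)c(C(=O)Nc2cnc3[nH]ncc3c2)c1F`) reaches 147000 ng.h/mL on the same read-out. Among the measured compounds shown here, compound 4 (`CCCS(=O)(=O)Nc1ccc(F)c(C(=O)Nc2cnc3[nH]nc(OC)c3c2)c1F`) carries methoxy in place of hydrogen on an aromatic carbon of compound 1 methoxy in place of hydrogen on an aromatic carbon as its one change. For the measured compounds named here, no measured step covers this change. Going by the values given here, the only step available, a 3.7-fold higher number from compound 1 to compound 2 (0.57 log units; beyond the scatter) with chloro in place of fluoro on an aromatic carbon, is a different change and bears on it only by showing how far this assay can move within this small set. The estimated step is therefore a 1.1-fold lower number from compound 1 to compound 4 (0.02 log units; within the scatter) and no move beyond the scatter is expected. Compound 4 is expected at 38000 ng.h/mL with a range from 15000 ng.h/mL to 100000 ng.h/mL in this estimate.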

Compound 4, area under the concentration-time curve: 190000 ng.h/mL
Beside the measured number, compound 4's estimate is 5.0-fold (0.70 log units) below it, outside the stated range (above it).
By their numbers in this assay, from the lowest: compounds 1 and 3 (each within the scatter of the next); then compounds 2 and 4 (each within the scatter of the next).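

With methoxy in place of hydrogen on this aromatic carbon, this assay shows a 4.8-fold higher number from compound 1 to compound 4 (0.68 log units; beyond the scatter). Among the compounds shown here, the only step readable before this was a chloro for fluoro change elsewhere in the molecule, so this is the first sign that a change on the five-membered aromatic ring itself can raise exposure beyond the scatter. Nothing available explains the rise. The compounds shown leave open whether an ethoxy group, an amine or a longer chain on this carbon would move exposure the same way, and whether methoxy here would combine with the chloro of compound 2.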